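Swapping the Side Chain of Compound 2

The source may hold more compounds than are shown below. What is called first, only, known or untested is meant among the compounds shown, and "the series" means these compounds.

Compound 1 `CN(C)CCCCCn1c2c(c3ccccc31)C(=O)c1c[n+]([O-])c3ccccc3c1C2=O`: 200 nM
Compound 2 `CN1CCN(CCCCn2c3c(c4ccccc42)C(=O)c2c[n+]([O-])c4ccccc4c2C3=O)CC1`: 100 nM
Compound 3 `O=C1c2c[n+]([O-])c3ccccc3c2C(=O)c2c1c1ccccc1n2CCN1CCCC1`: not yet measured

Going by the values given here, in a functional assay on MCF7 cells (Homo sapiens) for cytotoxicity, read by MTT assay, with a stated time of 72 h (a higher number here means a weaker inhibitor, a lower number a stronger inhibitor), compound 2 gives 100 nM, a value that cannot be separated from that of compound 1, since the only measured step is a 2.0-fold lower number from compound 1 to compound 2 (0.30 log units; within the scatter). Compound 3 has pyrrolidin-1-yl in place of 2-(4-methylpiperazin-1-yl)ethyl, on a saturated chain carbon, two bonds along the chain from an aromatic nitrogen: pyrrolidin-1-yl in place of 2-(4-methylpiperazin-1-yl)ethyl on a saturated chain carbon, two bonds along the chain from an aromatic nitrogen. That single step involved a different swap, so it offers only weak guidance, and no change beyond the scatter is expected. The expected change is a 1.5-fold higher number from compound 2 to compound 3 (0.18 log units; within the scatter). For compound 3, the estimate is 150 nM, within an expected range of 50 nM to 500 nM.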

Compound 3, half-maximal inhibitory concentration: 320 nM
For compound 3 the middle estimate is 2.1-fold (0.33 log units) below the measured one; the measured number falls inside the stated range.
By their numbers in this assay, from the lowest: compounds 2, 1 and 3 (each within the scatter of the next, the first and the last beyond it).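

In this assay, going by these compounds alone, the side chain on this aromatic nitrogen does matter: going from 4-(4-methylpiperazin-1-yl)butyl to 2-(pyrrolidin-1-yl)ethyl gives a 3.2-fold higher number from compound 2 to compound 3 (0.51 log units; beyond the scatter) and is the first step here to clear the scatter. The step of a 1.6-fold higher number from compound 1 to compound 3 (0.20 log units; within the scatter) leaves those two compounds inseparable, even though the side chain changes there too. Nothing available explains either step.

Chain and ring change together in compound 3, so their shares stay unresolved. A butyl chain ending in pyrrolidin-1-yl, or an ethyl chain ending in 4-methylpiperazin-1-yl, would separate them.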